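The source may hold more compounds than are shown below. What is called first, only, known or untested is meant among the compounds shown, and "the series" means these compounds.

In a functional assay on Jurkat cells (Homo sapiens) (on this read-out lower numbers stand for stronger inhibition and higher numbers for weaker inhibition), the measured compounds stand as follows.

Compound 1, `CC(C)[C@H](NC(=O)COc1cccc2ccccc12)C(=O)N[C@@H](CC(=O)O)C(=O)COC(=O)c1c(Cl)cccc1Cl`, gives 10600 nM.
Compound 2, `CC(C)[C@H](NC(=O)COc1cccc2ccccc12)C(=O)N[C@@H](CC(=O)O)C(=O)COc1ccccc1C(F)(F)F`, gives only a limit of the assay, > 100000 nM.
Compound 3, `CC(C)[C@H](NC(=O)COc1cccc2ccccc12)C(=O)N[C@@H](CC(=O)O)C(=O)COc1c(F)cc(F)cc1F`, gives 6840 nM.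

Compound 2 thus stands at the weak end of the numbers shown: its value is a limit rather than a number, and it sits at the limit of > 100000 nM in this assay, at which 1 of the 3 values shown sits. The measured steps around it are an at least 9.4-fold higher number from compound 1 to compound 2 (0.97 log units; beyond the scatter) and an at least 14-fold lower number from compound 2 to compound 3 (1.16 log units; beyond the scatter), while compound 1 and compound 3 differ only by a 1.5-fold lower number from compound 1 to compound 3 (0.19 log units; within the scatter).

Compound 4, `CC(C)[C@H](NC(=O)COc1cccc2ccccc12)C(=O)N[C@@H](CC(=O)O)C(=O)COc1c(F)c(F)cc(F)c1F`, is not yet measured. Its change from compound 2 is 2,3,5,6-tetrafluorophenyl in place of 2-(trifluoromethyl)phenyl on an oxygen on a saturated carbon. The step that bears on it is an at least 14-fold lower number from compound 2 to compound 3 (1.16 log units; beyond the scatter), in which a fluorinated phenyl likewise took the place of 2-(trifluoromethyl)phenyl on an oxygen on a saturated carbon and the number fell by a large margin. A step of similar kind is expected for compound 4, namely an at least 14-fold lower number from compound 2 to compound 4 (1.15 log units; beyond the scatter) in this assay, downward and beyond the scatter. Compound 4 is therefore estimated at 7000 nM in this assay, with a range from 2500 nM to 30000 nM.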

Compound 4, half-maximal inhibitory concentration: 4500 nM
Compound 4: middle estimate off by 1.6-fold (0.19 log units), on the high side, within the range that was stated.
By their numbers in this assay, from the lowest: compounds 4, 3 and 1 (each within the scatter of the next, the first and the last beyond it). At a limit, above all of these: compound 2.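

In this assay, a second fluorinated phenyl, 2,3,5,6-tetrafluorophenyl, replaces 2-(trifluoromethyl)phenyl on an oxygen on a saturated carbon and gives an at least 22-fold lower number from compound 2 to compound 4 (1.34 log units; beyond the scatter), so the large drop seen with compound 3 is not confined to 2,4,6-trifluorophenyl. The two fluorinated phenyls themselves cannot be told apart at this place, as the step between them is a 1.5-fold lower number from compound 3 to compound 4 (0.18 log units; within the scatter). The replacement of (2,6-dichlorophenyl)carbonyl now gives a step that clears the scatter, a 2.4-fold lower number from compound 1 to compound 4 (0.37 log units; beyond the scatter), whereas the same comparison with compound 3 stayed within it, although compound 3 and compound 4 remain within the scatter of each other.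

Going by these compounds, compound 2 remains a limit of the assay and not a number, so the full size of its steps stays open: the limit of > 100000 nM in this assay, at which 1 of the 4 values shown sits. The compounds shown also leave open how an unsubstituted phenyl, a 2-chlorophenyl or a 2-cyanophenyl would read on this oxygen, and so whether the trifluoromethyl group itself or the absence of ring fluorine separates compound 2 from compound 3 and compound 4.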